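A few compounds are considered here, and "the series" means these few. Any claim that something is new, unique, unknown or untested is made for them only; others in the source may bear on it.

Compound 2 `CC(C)n1cnc2c(Nc3cccc(Cl)c3)nc(NCOCc3ccc(C(=O)Nc4ccccc4N)cc3)nc21` gives 60.5% in a functional assay on HepG2 cells (Homo sapiens) for antiproliferative activity, read by CCK-8 assay, with a stated time of 72 h, tested at 8 uM (on this read-out lower numbers stand for a weaker effect and higher numbers for a stronger effect at the one concentration tested), the highest of the three numbers. Compound 1 `CC(C)n1cnc2c(Nc3ccccc3)nc(NCOCc3ccc(C(=O)Nc4ccccc4N)cc3)nc21` gives 50.2%, and the step of a number 10.3 percentage points higher from compound 1 to compound 2 (beyond the scatter) is modest but beyond the scatter. Compound 3 `CC(C)n1cnc2c(Nc3cccc(Cl)c3)nc(NCOCc3ccc(/C=C/C(=O)Nc4ccccc4N)cc3)nc21` gives 49.9%, with a number 10.6 percentage points lower from compound 2 to compound 3 (beyond the scatter). Compound 4 `CCCCn1cnc2c(Nc3cccc(Cl)c3)nc(NCOCc3ccc(C(=O)Nc4ccccc4N)cc3)nc21` differs from compound 2 by butyl in place of isopropyl on an aromatic nitrogen. Going by the values given here, neither measured step touches the group on the aromatic nitrogen: one concerns chloro in place of hydrogen, the other the carbamoyl group, so no measured step bears on this change. The step of a number 2.5 percentage points lower from compound 2 to compound 4 (within the scatter) is therefore expected to stay within the scatter, in no particular direction. Compound 4 is estimated at 58%, within a range from 45% to 70%.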

Compound 4, a percentage reported as inhibition, at one concentration (the size of the read-out at that concentration, not a potency): 63.1%
Compound 4: middle estimate off by 5.1 percentage points, on the low side; the range from low to high includes it.
By their numbers in this assay, from the lowest: compounds 3 and 1 (each within the scatter of the next); then compounds 2 and 4 (each within the scatter of the next).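

In this assay, going by these compounds alone, the first measured change at the aromatic nitrogen, butyl in place of isopropyl, gives a number 2.6 percentage points higher from compound 2 to compound 4 (within the scatter). With the rest of the structure kept, this position therefore accepts the unbranched butyl chain in place of the isopropyl group without a change beyond the scatter. Nothing available bears on why this is so. As far as these compounds go, whether a longer chain, a cyclopentyl ring or a chain ending in an amine would read the same remains open. So does whether butyl would do so in the core of compound 1 or compound 3.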